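The compounds below may be only part of what the source reports. "The series", "measured", "known", "first", "only" and "open" are said of these compounds alone.

Measured so far in a functional assay on HEK293 cells for antagonist activity at transient receptor potential cation channel subfamily V member 1 (Rattus norvegicus); a higher number here means a weaker inhibitor, a lower number a stronger inhibitor:

Compound 1 `CC(C)c1ccc(NC(=O)N2CCN(c3ncccc3Cl)CC2)cc1`: 11.5 nM
Compound 2 `CC(C)c1ccc(NC(=O)N2CCN(c3ncccc3Br)CC2)cc1`: 4.6 nM
Compound 3 `O=C(Nc1ccc(Cl)cc1)N1CCN(c2ncccc2Cl)CC1`: 655 nM

Compound 3 gives the highest of the three numbers in this assay. Its core differs from the core of compound 1 by chloro in place of isopropyl on an aromatic carbon, a step of a 57-fold higher number from compound 1 to compound 3 (1.76 log units; beyond the scatter). Compound 2 differs from compound 1 by bromo in place of chloro on an aromatic carbon, a step of a 2.5-fold lower number from compound 1 to compound 2 (0.40 log units; beyond the scatter).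

Compound 4 `O=C(Nc1ccc(Br)cc1)N1CCN(c2ncccc2Cl)CC1` is not yet measured. It differs from compound 3 by bromo in place of chloro on an aromatic carbon. Within the data shown here, this is the same kind of change as the one from compound 1 to compound 2, not the same: there the change sits on a six-membered aromatic ring with one nitrogen, ortho to a large group and two atoms from the ring nitrogen; here it sits on a six-membered aromatic ring of carbon only, para to a large group. Among the measured compounds shown here, only one measured pair shows this kind of change, so its direction rests on a single case in a different setting. The step in this assay is expected to be modest, a 1.6-fold lower number from compound 3 to compound 4 (0.19 log units; within the scatter), because the earlier step of a 2.5-fold lower number from compound 1 to compound 2 (0.40 log units; beyond the scatter) was itself modest. Compound 4 is estimated at 420 nM, between 150 nM and 1100 nM.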

Compound 4, half-maximal inhibitory concentration: 491 nM
Compound 4: the middle estimate sits 1.2-fold (0.07 log units) below what was measured; the range from low to high includes it.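

In this assay, bromo in place of chloro on the ring of carbon only gives a 1.3-fold lower number from compound 3 to compound 4 (0.13 log units; within the scatter), whereas bromo in place of isopropyl gives a 43-fold higher number from compound 1 to compound 4 (1.63 log units; beyond the scatter), so on these compounds the exchange of one halogen for the other moves the number far less than the loss of isopropyl does. Among these compounds, the halogen exchange does not separate the two cores: the same change on two cores in this assay, a 2.5-fold lower number (0.40 log units; beyond the scatter) from compound 1 to compound 2 and a 1.3-fold lower number (0.13 log units; within the scatter) from compound 3 to compound 4, 1.9-fold (0.27 log units) apart, within the scatter of two such steps This fits a small step that carries from one core to the other, but two pairs with the change at different places neither fix its size nor confirm its direction, as only the step on compound 1 lies beyond the scatter.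

Still open, as far as these compounds go, is whether a tert-butyl or trifluoromethyl group in place of the bromo of compound 4 would bring the number back towards that of compound 1. Also open, from the compounds shown here alone, is how a nitrile or a methoxy group would read in place of the halogen on the ring with one nitrogen.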